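Adding a Second Chloro to the Core of Compound 1

This account rests on a few compounds, and the source may have more. Where it says the series, first, only, none or still open, it means among the compounds named here.

Measured compounds:
compound 1 `ClCc1ccc(Cn2cnc3c(Cl)ncnc32)cc1`: 3010 nM
compound 2 `ClCc1cccc(Cn2cnc3c(Cl)nc(Cl)nc32)c1`: 3090 nM

In a functional assay on U-251 cells (Homo sapiens) for cytotoxicity, read by sulforhodamine B assay, with a stated time of 48 h (on this read-out higher numbers stand for weaker inhibition of growth and lower numbers for stronger inhibition of growth), compound 1 gives 3010 nM, the lowest of the two numbers shown, and compound 2 gives 3090 nM, which lies within the scatter of that number. Compound 3 `ClCc1ccc(Cn2cnc3c(Cl)nc(Cl)nc32)cc1` has not been measured. It differs from compound 1 by chloro in place of hydrogen on an aromatic carbon. Going by the values given here, no measured pair shows this change on its own. Compound 2 carries the same two chloro groups on its core and its value sits within the scatter of compound 1, so the step from compound 1 to compound 3 is expected to be a 1.0-fold lower number from compound 1 to compound 3 (0.00 log units; within the scatter), none beyond the scatter. Compound 3 is therefore expected at 3000 nM, with a range from 1200 nM to 7500 nM.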

Compound 3, concentration for total growth inhibition: 3890 nM
Compound 3: the middle estimate sits 1.3-fold (0.11 log units) below what was measured; low and high end bracket the measured number.
By their numbers in this assay, from the lowest: compounds 1, 2 and 3 (each within the scatter of the next).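

In this assay, going by these compounds alone, chloro in place of hydrogen on the aromatic carbon between two ring nitrogen atoms gives a 1.3-fold higher number from compound 1 to compound 3 (0.11 log units; within the scatter), the first reading of this change on its own. This position therefore takes a chloro group with no change that can be told from the scatter. Nothing measured here gives a reason for this result. Still open, from the compounds shown here alone, is whether an amine or a methoxy group on this same carbon would move the number beyond the scatter. Also open, going by these compounds, is whether this result would hold with a hydroxymethyl group in place of the chloromethyl group.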